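The source may hold more compounds than are shown below. What is called first, only, known or untested is meant among the compounds shown, and "the series" means these compounds.

In a functional assay on WM-115 cells (Homo sapiens) for cytotoxicity, read by MTT assay, with a stated time of 46 h (on this read-out lower numbers stand for stronger inhibition and higher numbers for weaker inhibition), three compounds sharing one core have been measured. Compound 1 `O=C1/C(=C\c2ccccc2)C(c2ccccc2)Oc2ccccc21` gives 52600 nM, compound 2 `Cc1ccc(/C=C2\C(=O)c3ccccc3OC2c2ccccc2)cc1` gives 57000 nM and compound 3 `O=C1/C(=C\c2ccc(Cl)cc2)C(c2ccccc2)Oc2ccccc21` gives 27400 nM. The standing of compound 3 rests on two steps: a 2.1-fold lower number from compound 2 to compound 3 (0.32 log units; beyond the scatter) and a 1.9-fold lower number from compound 1 to compound 3 (0.28 log units; within the scatter). Only the first lies beyond the scatter, and it is modest.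

Compound 4 `O=C1/C(=C\c2ccc(Br)cc2)C(c2ccccc2)Oc2ccccc21` has not yet been measured. Its difference from compound 3 is bromo in place of chloro on an aromatic carbon. In words, this is bromo in place of chloro on an aromatic carbon of a six-membered aromatic ring of carbon only, para to a large group, so that 4-chlorophenyl becomes 4-bromophenyl.

Among the compounds with values here, no measured compound carries bromo, so the evidence is indirect. Three exchanges on an aromatic carbon bear on the change, and all are small: a 1.1-fold higher number from compound 1 to compound 2 (0.03 log units; within the scatter), together with the two steps involving compound 3 above. Even the exchange of chloro for methyl, at a 2.1-fold lower number from compound 2 to compound 3 (0.32 log units; beyond the scatter), barely passes the scatter. No step beyond the scatter is therefore expected in this assay, and the estimated change is a 1.0-fold lower number from compound 3 to compound 4 (0.01 log units; within the scatter). For compound 4 the expected value is 27000 nM, with an estimated range from 13000 nM to 55000 nM.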

Compound 4, half-maximal inhibitory concentration: 32600 nM
Beside the measured number, compound 4's estimate is 1.2-fold (0.08 log units) below it; measured number inside the range.
By their numbers in this assay, from the lowest: compounds 3, 4, 1 and 2 (each within the scatter of the next, the first and the last beyond it).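

In this assay, bromo in place of chloro on an aromatic carbon, para to a large group, gives a 1.2-fold higher number from compound 3 to compound 4 (0.08 log units; within the scatter), so the compounds carrying these two groups cannot be told apart here. Within the data shown here, compound 4 also stands within the scatter of the compounds carrying methyl and hydrogen, with a 1.7-fold lower number from compound 2 to compound 4 (0.24 log units; within the scatter) and a 1.6-fold lower number from compound 1 to compound 4 (0.21 log units; within the scatter), so the only step beyond the scatter at this position remains the modest one of chloro in place of methyl, a 2.1-fold lower number from compound 2 to compound 3 (0.32 log units; beyond the scatter), and bromo in place of methyl does not repeat it. No measurement is available that would account for the size of any of these steps.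

Going by these compounds, the four compounds carry only hydrogen, methyl, chloro or bromo at this one position, so it remains open whether a group of another kind here, such as an amine, a carboxylic acid or a longer chain, would shift the number by more than the scatter. Also open, on these data alone, is whether the same exchanges would give equally small steps on the other phenyl ring of the shared core, or in a different cell line.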